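Oxane substituent changes in a 5-lipoxygenase series

A few compounds are considered here, and "the series" means these few. Any claim that something is new, unique, unknown or untested is made for them only; others in the source may bear on it.

Measured so far:
compound 1 `CC(=O)C1(c2cc(F)cc(OCc3ccc(-n4ccnc4C)cc3)c2)CCOCC1` — 130 nM
compound 2 `Cc1nccn1-c1ccc(COc2cc(F)cc(C3(C(N)=O)CCOCC3)c2)cc1` — 340 nM
compound 3 `COC1(c2cc(F)cc(OCc3ccc(-n4ccnc4C)cc3)c2)CCOCC1` — 60 nM

In an assay on blood for inhibition of Polyunsaturated fatty acid 5-lipoxygenase (Homo sapiens) (on this read-out higher numbers stand for weaker inhibition and lower numbers for stronger inhibition), compound 1 stands second highest of the three numbers, with compound 3 nearest and compound 2 furthest. The step to compound 4 `Cc1nccn1-c1ccc(COc2cc(F)cc(C3(S(C)(=O)=O)CCOCC3)c2)cc1` is methylsulfonyl in place of acetyl on a saturated ring carbon. The closest precedents replace the same acetyl group on the oxane carbon: a 2.2-fold lower number from compound 1 to compound 3 (0.34 log units; beyond the scatter) and, on the carbonyl carbon, a 2.6-fold higher number from compound 1 to compound 2 (0.42 log units; beyond the scatter). Both are modest, so a modest step in this assay is expected, most plausibly toward a higher number, as seen when the carbamoyl group entered. For compound 4 the expected step is a 1.5-fold higher number from compound 1 to compound 4 (0.19 log units; within the scatter), giving an estimate of 200 nM with a range from 70 nM to 600 nM.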

Compound 4, half-maximal inhibitory concentration: > 1000 nM
Compound 4: only a limit was reported (the forecaster's own chance of this, stated with the estimate: 3%); middle value at least 5.0-fold (0.69 log units) away from the limit.
By their numbers in this assay, from the lowest: compound 3; then compound 1; then compound 2. At a limit, above all of these: compound 4.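

In this assay compound 4 gives only a limit, not a number: the limit of > 1000 nM in this assay, at which 1 of the 4 values shown sits.

Methylsulfonyl is the weakest of the four groups on this saturated ring carbon, with an at least 7.6-fold higher number from compound 1 to compound 4 (0.88 log units; beyond the scatter), an at least 2.9-fold higher number from compound 2 to compound 4 (0.46 log units; beyond the scatter) and an at least 16-fold higher number from compound 3 to compound 4 (1.22 log units; beyond the scatter). Within the data shown here, this last step exceeds the widest gap among the earlier groups, a 5.7-fold lower number from compound 2 to compound 3 (0.75 log units; beyond the scatter), so this position tolerates some changes far less well than the earlier compounds suggested.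

From the compounds shown here alone, the true value of compound 4 beyond its limit remains open. So does how an amine or a carboxylic acid on this ring carbon would read.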